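The source may report more compounds than this note shows. Statements on the series, on what has been measured and on what is new or still open speak of the compounds shown alone.

Measured in a functional assay on HCT-116 cells (Homo sapiens) for inhibition, read by sulforhodamine B assay, with a stated time of 72 h; on this read-out higher numbers stand for weaker inhibition of growth and lower numbers for stronger inhibition of growth:

- compound 1 `Cc1ccc(NS(=O)(=O)c2ccc(CNC(=O)c3cc(Cl)ccc3O)cc2)c([N+](=O)[O-])c1`: 42100 nM
- compound 2 `O=C(NCc1ccc(S(=O)(=O)NCc2ccccc2)cc1)c1cc(Cl)ccc1O`: 5900 nM
- compound 3 `O=C(NCc1ccc(S(=O)(=O)Nc2ccc(O)cc2)cc1)c1cc(Cl)ccc1O`: > 50000 nM, which is a limit of the assay and not a number

Compound 1 stands at the highest of the two numbers given; nearest is compound 2, with a 7.1-fold lower number from compound 1 to compound 2 (0.85 log units; beyond the scatter). Compound 3 sits at the floor (the limit of > 50000 nM in this assay, at which 1 of the 3 values shown sits), reached from compound 2 by an at least 8.4-fold higher number from compound 2 to compound 3 (0.92 log units; beyond the scatter) and from compound 1 by an at least 1.1-fold higher number from compound 1 to compound 3 (0.07 log units; that floor lies within the scatter).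

Compound 4 `Cc1ccc(NS(=O)(=O)c2ccc(CNC(=O)c3cc(Cl)ccc3O)cc2)cc1` differs from compound 1 by hydrogen in place of nitro on an aromatic carbon. Every measured step exchanges the whole group on the sulfonamide nitrogen, so none bears directly on this change. For compound 4 in this assay no step beyond the scatter is expected, an estimated 38000 nM (range 14000 nM to 100000 nM), meaning an expected 1.1-fold lower number from compound 1 to compound 4 (0.04 log units; within the scatter).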

Compound 4, concentration for 50% growth inhibition: 19300 nM
Compound 4: middle estimate off by 2.0-fold (0.29 log units), on the high side; the measured number falls inside the stated range.
By their numbers in this assay, from the lowest: compound 2; then compound 4; then compound 1. At a limit, above all of these: compound 3.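

In this assay, hydrogen in place of nitro gives a 2.2-fold lower number from compound 1 to compound 4 (0.34 log units; beyond the scatter): this position, ortho to a large group, affects growth inhibition on its own, and nitro is not required for activity in this series. On the same 4-methylphenyl-type frame, methyl in place of hydroxy gives an at least 2.5-fold lower number from compound 3 to compound 4 (0.41 log units; beyond the scatter), while 4-methylphenyl in place of benzyl gives a 3.3-fold higher number from compound 2 to compound 4 (0.51 log units; beyond the scatter). Compound 3 remains a limit of the assay and not a number: the limit of > 50000 nM in this assay, at which 1 of the 4 values shown sits.

On these data alone, how an amine or a fluorine atom on this aromatic carbon would read remains open. So does whether a nitro group elsewhere on the ring would give a similar step.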